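A few compounds are considered here, and "the series" means these few. Any claim that something is new, unique, unknown or untested is made for them only; others in the source may bear on it.

In an assay on membranes from CHO cells for displacement of a labelled ligand from adenosine receptor A1 (Homo sapiens), read by scintillation counting, with a stated time of 60 min, tested at 1 uM (a higher number here means more inhibition at the concentration tested (going by the name of the read-out), a lower number less inhibition), the measured compounds gave:
compound 1 `CCCOC(=O)C1=C(C)NC(=O)NC1c1ccoc1`: 50%
compound 2 `CCCOC(=O)C1=C(C)NC(=O)NC1c1ccsc1`: 44%
compound 3 `CC1=C(C(=O)OCc2ccccc2)C(c2ccsc2)NC(=O)N1`: 57%

Compound 2 is not clearly separated from compound 1, since the step of a number 6 percentage points lower from compound 1 to compound 2 (within the scatter) is within the scatter, whereas the step of a number 13 percentage points higher from compound 2 to compound 3 (beyond the scatter) is beyond it, so of the three only compound 3 stands clearly apart from compound 2. Compound 4 `CC1=C(c2ncc(C)o2)C(c2ccsc2)NC(=O)N1` has not been measured in this assay. It differs from compound 2 in one place: 5-methyl-1,3-oxazol-2-yl in place of propoxycarbonyl on a double-bonded ring carbon. Neither measured step bears directly on this change. The step from compound 1 to compound 2 exchanged the group on the saturated ring carbon, and the step from compound 2 to compound 3 changed the chain on the oxygen next to the carbonyl group, while in compound 4 the propoxycarbonyl group is gone altogether and an aromatic ring takes its place on the double-bonded ring carbon. Within the data shown here, with no comparable step among the measured compounds, the expected step of a number 4 percentage points lower from compound 2 to compound 4 (within the scatter) is set close to zero, with a wide range around it. Compound 4 is therefore expected to give about 40% in this assay, within a range from 15% to 70%.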

Compound 4, a percentage reported as inhibition, at one concentration (the size of the read-out at that concentration, not a potency): 34%
The estimate for compound 4 lay 6 percentage points above the measured number; the measured number falls inside the stated range.
By their numbers in this assay, from the lowest: compounds 4, 2, 1 and 3 (each within the scatter of the next, the first and the last beyond it).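

Exchanging propoxycarbonyl for 5-methyl-1,3-oxazol-2-yl on the double-bonded ring carbon gave, in this assay, a number 10 percentage points lower from compound 2 to compound 4 (within the scatter), the first change shown at this position. The two groups match in heavy atoms and hydrogen-bond acceptors, and compound 4 still gives 34%, so a measurable read-out at this position does not require the carbonyl group of propoxycarbonyl, at least with thiophen-3-yl on the saturated ring carbon. No measurement is available that explains why the read-out stays within the scatter across this exchange.

The compounds shown leave open how a carboxylic acid, a primary amide or an unsubstituted 1,3-oxazol-2-yl would read at this position. They also leave open whether the exchange would give a similar step with furan-3-yl on the saturated ring carbon.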